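The source may report more compounds than this note shows. Statements on the series, on what has been measured and on what is new or still open speak of the compounds shown alone.

Working notes on the series. In an assay on isolated protein for inhibition of DNA topoisomerase 1 (Homo sapiens), with a stated time of 30 min, tested at 100 uM (on this read-out lower numbers stand for a weaker effect and higher numbers for a stronger effect at the one concentration tested), compound 1 `CCN(CC)c1ccc2nc(-c3ccccc3OC(F)(F)F)[nH]c(=O)c2c1` gives 81.2%, compound 2 `Cc1ccc2nc(-c3ccccc3C)[nH]c(=O)c2c1` gives 0% and compound 3 `Cc1ccc2nc(-c3ccccc3F)[nH]c(=O)c2c1` gives 67.9%. Compound 3 stands second highest of the three numbers: compound 1 sits beyond the scatter above it, compound 2 far below it. Going by the values given here, the one single-point step measured so far is a number 67.9 percentage points higher from compound 2 to compound 3 (beyond the scatter).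

Compound 4 `Cc1ccc2nc(-c3ccccc3OC(F)(F)F)[nH]c(=O)c2c1` is not yet measured. It differs from compound 3 by trifluoromethoxy in place of fluoro on an aromatic carbon. Among the compounds with values here, no measured step exchanges fluoro for trifluoromethoxy on the same core, so the step from compound 2 to compound 3 bears on it only indirectly, by showing that the fluoro compound already reaches a high number. Within the data shown here, compound 1 carries the same trifluoromethoxy group on a differently substituted core and gives 81.2%; no step between compound 1 and compound 4 is measured, so the two values can only be set side by side.

In this assay compound 4 is therefore expected to land close to compound 3, with a step of a number 4.1 percentage points higher from compound 3 to compound 4 (within the scatter) expected. The estimate for compound 4 is 72%, in a range from 45% to 92%.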

Compound 4, a percentage reported as inhibition, at one concentration (the size of the read-out at that concentration, not a potency): 66.9%
Compound 4: the middle estimate sits 5.1 percentage points above what was measured, within the range that was stated.
By their numbers in this assay, from the lowest: compound 2; then compounds 4 and 3 (each within the scatter of the next); then compound 1.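

In this assay, going by these compounds alone, the exchange of fluoro for trifluoromethoxy gives a number 1 percentage points lower from compound 3 to compound 4 (within the scatter) even though the entering group is much larger by heavy-atom count, while the exchange of methyl for trifluoromethoxy gives a number 66.9 percentage points higher from compound 2 to compound 4 (beyond the scatter) and so matches a number 67.9 percentage points higher from compound 2 to compound 3 (beyond the scatter) in direction, leaving methyl as the one group of the three at this position with a printed value of zero. With trifluoromethoxy held fixed, the other substituent also matters, as methyl in place of diethylamino gives a number 14.3 percentage points lower from compound 1 to compound 4 (beyond the scatter) and that step lies beyond the scatter. No measurement shown here gives a reason for any of these steps.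

Going by these compounds, whether a chlorine, a methoxy group or a primary amine at this position behaves like fluoro or like methyl remains open. Also open, on these data alone, is whether fluoro on the core of compound 1 would give the same number as trifluoromethoxy there.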